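Swapping Methyl for Fluoro on the Cyanophenyl Carbamate

The source may report more compounds than this note shows. Statements on the series, on what has been measured and on what is new or still open speak of the compounds shown alone.

Measured so far:
compound 1 `N#Cc1cccc(OC(=O)N2CCC(C(c3ccccc3)c3ccccc3)CC2)c1`: 36.5 nM
compound 2 `Cc1cc(C#N)cc(OC(=O)N2CCC(C(c3ccccc3)c3ccccc3)CC2)c1`: 150 nM

In an assay on isolated protein for inhibition of Monoglyceride lipase (Rattus norvegicus), read by fluorescence, with stated times of 15 min and 3 h (on this read-out lower numbers stand for stronger inhibition and higher numbers for weaker inhibition), compound 1 `N#Cc1cccc(OC(=O)N2CCC(C(c3ccccc3)c3ccccc3)CC2)c1` gives 36.5 nM. Compound 2 `Cc1cc(C#N)cc(OC(=O)N2CCC(C(c3ccccc3)c3ccccc3)CC2)c1`, which carries a methyl on the same aromatic ring, gives 150 nM. Compound 2 thus stands at the higher of the two numbers, the weaker end, separated from compound 1 by a 4.1-fold higher number from compound 1 to compound 2 (0.61 log units; beyond the scatter).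

Compound 3 `N#Cc1cc(F)cc(OC(=O)N2CCC(C(c3ccccc3)c3ccccc3)CC2)c1` has not yet been measured. It differs from compound 2 in one place: fluoro in place of methyl on an aromatic carbon. Going by the values given here, only one measured step speaks to this position, a 4.1-fold higher number from compound 1 to compound 2 (0.61 log units; beyond the scatter), which shows that a methyl at this carbon gives a modestly higher number than hydrogen. Fluoro is a different group from both, so the outcome is uncertain, but a number between those of compound 1 and compound 2 seems the most reasonable expectation. Compound 3 is therefore expected to show a 2.5-fold lower number from compound 2 to compound 3 (0.40 log units; beyond the scatter). On that basis compound 3 is estimated at 60 nM, with a range from 25 nM to 150 nM.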

Compound 3, half-maximal inhibitory concentration: 105 nM
Estimate against measurement, compound 3: 1.8-fold (0.24 log units) below, within the range that was stated.
By their numbers in this assay, from the lowest: compound 1; then compounds 3 and 2 (each within the scatter of the next).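

In this assay, fluoro and methyl at this carbon cannot be told apart, as the step between them is a 1.4-fold lower number from compound 2 to compound 3 (0.15 log units; within the scatter). Fluoro is nevertheless separated from hydrogen, with a 2.9-fold higher number from compound 1 to compound 3 (0.46 log units; beyond the scatter), so the higher number at this position now appears with two different groups rather than with methyl alone. Nothing measured here explains why either group differs from hydrogen.

The compounds shown hold only hydrogen, methyl and fluoro at this carbon, so it remains open whether other groups would also sit with compound 2 and compound 3 or would come closer to compound 1. A chlorine atom, a methoxy group or an amine at this carbon would test how general the pattern is.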